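This account rests on a few compounds, and the source may have more. Where it says the series, first, only, none or still open, it means among the compounds named here.

Compound 1 `CCN(Cc1cccs1)C(=O)COc1ccc(C)cc1` is the starting point. Going by the values given here, in an assay on HEK293 cells for agonist activity at transient receptor potential cation channel subfamily M member 8 (Homo sapiens), read by fluorescence and calcium flux, with a stated time of 15 min (a lower number here means that less compound is needed, a higher number that more compound is needed for the effect), compound 1 gives 8 nM, which is the higher of the two numbers measured so far. Among the compounds with values here, the only other measured compound is compound 2 `Cc1ccc(OCC(=O)N(Cc2cccs2)c2c[nH]nc2C)cc1`, which in this assay gives 0.4 nM. The step between them, a 20-fold lower number from compound 1 to compound 2 (1.30 log units; beyond the scatter), comes from swapping the group on the amide-type nitrogen, a place that compound 3 leaves exactly as it is in compound 1.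

Compound 3 `CCN(Cc1ccccn1)C(=O)COc1ccc(C)cc1` has not yet been measured. It differs from compound 1 in a single place: pyridin-2-yl in place of thiophen-2-yl on a saturated chain carbon bound to an amide-type nitrogen. The rest of the molecule, the shared core with its amide and its ether-linked ring, is unchanged.

Within the data shown here, no measured step touches this position, so there is no direct precedent for sizing the change. The expectation is therefore a step within the usual scatter, with only a mild lean toward a higher number, expressed as a 1.9-fold higher number from compound 1 to compound 3 (0.27 log units; within the scatter). Compound 3 is thus estimated at 15 nM in this assay, with a range from 4 nM to 60 nM.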

Compound 3, half-maximal effective concentration: 16000 nM
Beside the measured number, compound 3's estimate is 1100-fold (3.03 log units) below it; measured number outside the range, above it.
By their numbers in this assay, from the lowest: compound 2; then compound 1; then compound 3.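

The group on the saturated chain carbon bound to an amide-type nitrogen matters greatly in this assay, where pyridin-2-yl in place of thiophen-2-yl gives a 2000-fold higher number from compound 1 to compound 3 (3.30 log units; beyond the scatter), so one aromatic ring cannot freely stand in for another at this position. On paper the swap looks modest: each group is a single aromatic ring with one hetero atom, the counts of hydrogen-bond donors and acceptors match, and neither carries a net charge, so these counts do not separate the two compounds, while ring size and the identity of the hetero atom do. Nothing available here accounts for the size of this step, and its cause remains unknown.

A single swap cannot show whether the step follows the six-membered ring or the ring nitrogen, a question that phenyl, a six-membered ring of carbon alone, and furan-2-yl, a five-membered ring with oxygen, could help to separate. Also open, going by these compounds, are whether pyridin-3-yl, with its nitrogen placed differently, would behave like pyridin-2-yl, and whether the 3-methyl-1H-pyrazol-4-yl group of compound 2 would change the outcome of this swap.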